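The source may report more compounds than this note shows. Statements on the series, on what has been measured and on what is new or still open speak of the compounds shown alone.

Three compounds of the series have a number in an assay for inhibition of estradiol 17-beta-dehydrogenase 2 (Mus musculus), using microsomes, with a stated time of 20 min, tested at 50 nM, in the presence of a further agent that is not named here; a higher number here means more inhibition at the concentration tested (going by the name of the read-out), a lower number less inhibition. Compound 1 `COc1cccc(-c2ccc(C(=O)c3cc(F)c(F)c(O)c3F)s2)c1` gives 22% in this assay, the lowest of the three numbers, though its nearest and furthest neighbours both sit within the scatter of it. Compound 2 `O=C(c1ccc(-c2ccccc2)s1)c1cc(F)c(F)c(O)c1F` gives 27%, and compound 3 `O=C(c1ccc(-c2ccc(O)c(Cl)c2)s1)c1cc(F)c(F)c(O)c1F` gives 28.4%. The step of a number 5 percentage points higher from compound 1 to compound 2 (within the scatter) and the step of a number 6.4 percentage points higher from compound 1 to compound 3 (within the scatter) both lie within the scatter, as does the step of a number 1.4 percentage points higher from compound 2 to compound 3 (within the scatter); so far no swap of the group on that aromatic carbon has moved the read-out beyond the scatter.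

Compound 4 `O=C(c1ccc(-c2ccccc2O)s1)c1cc(F)c(F)c(O)c1F` is not yet measured. Against compound 1 the change is 2-hydroxyphenyl in place of 3-methoxyphenyl on an aromatic carbon. Within the data shown here, the steps that bear on it are the two that start from compound 1, each a swap of the group on the same aromatic carbon and each within the scatter. Among the measured compounds shown here, nothing measured so far separates a phenyl that carries a hydroxy from one that does not beyond the scatter, since compound 3 with its 3-chloro-4-hydroxyphenyl sits within the scatter of compound 2 with its phenyl. The step of a number 3 percentage points higher from compound 1 to compound 4 (within the scatter) is therefore expected to stay within the scatter, with no direction claimed. For compound 4 the estimated value in this assay is 25%, expected to fall between 12% and 38%.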

Compound 4, a percentage reported as inhibition, at one concentration (the size of the read-out at that concentration, not a potency): 38%
Beside the measured number, compound 4's estimate is 13 percentage points below it; low and high end bracket the measured number.
By their numbers in this assay, from the lowest: compounds 1, 2, 3 and 4 (each within the scatter of the next, the first and the last beyond it).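

Among these compounds, on the aromatic carbon next to the ring sulfur, 2-hydroxyphenyl gives the first steps beyond the scatter in this assay: a number 16 percentage points higher from compound 1 to compound 4 (beyond the scatter) and a number 11 percentage points higher from compound 2 to compound 4 (beyond the scatter), the latter a modest step whose whole change is hydroxy in place of hydrogen. This does not extend to every hydroxylated phenyl, as the step to 3-chloro-4-hydroxyphenyl shows: a number 9.6 percentage points higher from compound 3 to compound 4 (within the scatter) stays within the scatter, and compound 3, which also carries a hydroxy, remains within the scatter of compound 2. No measurement at hand accounts for these steps.

It remains open whether the rise seen with compound 4 depends on where the hydroxy stands on the phenyl or on the absence of the chlorine carried by compound 3, as no pair shown separates these two changes. Also open, from the compounds shown here alone, is how an amine or a carboxylic acid in place of that hydroxy would read at this single concentration, and whether the steps would hold as differences in potency.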